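Replacing the Sulfur-Bound Ring at the Chain End

A few compounds are considered here, and "the series" means these few. Any claim that something is new, unique, unknown or untested is made for them only; others in the source may bear on it.

Measured so far:
compound 1, `Cc1nnc(SCC(=O)Nc2ccc(-c3nc(-c4ccccc4)c(-c4ccccc4)n3C)cc2)s1`: 37.5%
compound 2, `Cn1c(-c2ccc(NC(=O)CSC3=NCCS3)cc2)nc(-c2ccccc2)c1-c1ccccc1`: 16.2%

Two compounds share a core and differ only in the group carried on the sulfur. In a functional assay on MCF7 cells (Homo sapiens) for cytotoxicity, read by MTT assay, with a stated time of 24 h, tested at 1.6 ug/mL (on this read-out lower numbers stand for a weaker effect and higher numbers for a stronger effect at the one concentration tested), compound 1 gives 37.5%, while compound 2 gives 16.2%. Within the data shown here, the one step between them is a number 21.3 percentage points lower from compound 1 to compound 2 (beyond the scatter). Among the measured compounds shown here, compound 2 therefore stands at the lower of the two numbers, with compound 1 the only neighbour, and the gap between them is beyond the scatter.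

Compound 3, `CN(C)/C=C/N1CCN(CC(=O)Nc2ccc(-c3nc(-c4ccccc4)c(-c4ccccc4)n3C)cc2)CC1`, is not yet measured. It differs from compound 2 by a group of 11 heavy atoms (8 carbon, 3 nitrogen; one six-membered non-aromatic ring with 2 hetero atoms) in place of a group of 6 heavy atoms (3 carbon, 1 nitrogen, 2 sulfur; one five-membered non-aromatic ring with 2 hetero atoms), on a saturated chain carbon bound to a carbonyl carbon. For the measured compounds named here, only one measured step exists, and it concerns an exchange on the sulfur; here the sulfur itself leaves with its ring. That step is only a loose guide: it shows that changing this part of the molecule moved the read-out by a modest amount. Because of a number 21.3 percentage points lower from compound 1 to compound 2 (beyond the scatter), a step of similar size in either direction is plausible, with no firm ground for choosing one. Compound 3 is therefore expected near compound 2, with a step estimated at a number 7.8 percentage points higher from compound 2 to compound 3 (within the scatter). The estimate for compound 3 is 24%, within a range from 6% to 48%.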

Compound 3, a percentage reported as activity, at one concentration (the size of the read-out at that concentration, not a potency): 1.9%
Beside the measured number, compound 3's estimate is 22.1 percentage points above it, outside the stated range (below it).
By their numbers in this assay, from the lowest: compound 3; then compound 2; then compound 1.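

In this assay, the exchange on the saturated chain carbon bound to a carbonyl carbon gives a number 14.3 percentage points lower from compound 2 to compound 3 (beyond the scatter) and, measured against the other sulfur-bearing compound, a number 35.6 percentage points lower from compound 1 to compound 3 (beyond the scatter). Where the earlier step only swapped one ring for another on a sulfur, this change removes the sulfur and its ring together and brings in 4-(2-(dimethylamino)ethenyl)piperazin-1-yl, and the read-out falls further even though the group leaving compound 2 and the group entering compound 3 have equal counts of hydrogen-bond donors and acceptors. Nothing at hand explains why the read-out falls with this exchange.

The compounds shown leave open whether the fall belongs to the piperazine ring itself or to the 2-(dimethylamino)ethenyl group it carries, a question that an unsubstituted piperazine or a 4-methylpiperazine at the same place would address. They also leave open how a morpholine ring or a plain dimethylamino group on that chain carbon would compare with the sulfur-linked rings, and whether a sulfur link bearing an open chain rather than a ring would keep the higher numbers.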